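Second bromine on the hydroxyphenyl hydrazone

This account rests on a few compounds, and the source may have more. Where it says the series, first, only, none or still open, it means among the compounds named here.

Among the measured compounds shown here, compound 2 `O=C(CSc1nnc(-c2ccncc2)n1-c1ccccc1)N/N=C/c1cc(Br)ccc1O` gives 1990 nM in a functional assay on HCT-116 cells (Homo sapiens) for inhibition, read by MTT assay, with a stated time of 48 h (a higher number here means a weaker inhibitor, a lower number a stronger inhibitor), the lowest of the two numbers so far; compound 1 `O=C(CSc1nnc(-c2ccncc2)n1-c1ccccc1)N/N=C/c1ccccc1F` gives 18000 nM. For the measured compounds named here, the one measured step, a 9.0-fold lower number from compound 1 to compound 2 (0.96 log units; beyond the scatter), exchanged the whole aryl group rather than adding a single substituent. Compound 3 `O=C(CSc1nnc(-c2ccncc2)n1-c1ccccc1)N/N=C/c1cc(Br)cc(Br)c1O` carries bromo in place of hydrogen on an aromatic carbon. Going by the values given here, no measured step adds a second bromo to an already substituted ring, so the measured steps bear on this change only loosely, and a small shift at most is expected in this assay, plausibly within the scatter. For compound 3 the estimated value is 1500 nM, with a range from 500 nM to 5000 nM. This estimate for compound 3 means an expected step of a 1.3-fold lower number from compound 2 to compound 3 (0.12 log units; within the scatter).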

Compound 3, half-maximal inhibitory concentration: 4500 nM
Estimate against measurement, compound 3: 3.0-fold (0.48 log units) below, within the range that was stated.
By their numbers in this assay, from the lowest: compound 2; then compound 3; then compound 1.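

In this assay, bromo on the aromatic carbon ortho to a hydroxy group gives a weaker result (a 2.3-fold higher number from compound 2 to compound 3 (0.35 log units; beyond the scatter)), so this second bromo brings no gain over the 5-bromo-2-hydroxyphenyl group. The 3,5-dibromo-2-hydroxyphenyl group still stands ahead of 2-fluorophenyl (a 4.0-fold lower number from compound 1 to compound 3 (0.60 log units; beyond the scatter)). No measured evidence bears on the reason for this loss. On these data alone, whether the loss is specific to bromo at this position remains open; a chloro, methoxy or amino group there would test it. As far as these compounds go, the contribution of the hydroxy group also remains open.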